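Acetyl on the amine nitrogen of compound 3

A few compounds are considered here, and "the series" means these few. Any claim that something is new, unique, unknown or untested is made for them only; others in the source may bear on it.

In a functional assay on 3T3-L1 cells (Mus musculus) for inhibition, with a stated time of 20 min, tested at 20 uM (on this read-out lower numbers stand for less inhibition and higher numbers for more inhibition at the one concentration tested (going by the name of the read-out)), compound 3 `Cc1ccc(S(=O)(=O)n2cc(CNCc3cccc(F)c3F)c3ccccc32)cc1` gives 46%, the highest of the three measured values. Compound 1 `Cc1ccc(S(=O)(=O)N(Cc2cccc(F)c2F)Cc2cn(S(=O)(=O)c3ccc(C)cc3)c3ccccc23)cc1` gives -13.9% and compound 2 `Cc1ccc(S(=O)(=O)n2cc(CN(Cc3ccccc3)Cc3cccc(F)c3F)c3ccccc32)cc1` gives -13.1%; both carry a substituent on the amine nitrogen that is unsubstituted in compound 3, and the steps of a number 59.9 percentage points higher from compound 1 to compound 3 (beyond the scatter) and a number 59.1 percentage points higher from compound 2 to compound 3 (beyond the scatter) were large. Compound 4 `CC(=O)N(Cc1cccc(F)c1F)Cc1cn(S(=O)(=O)c2ccc(C)cc2)c2ccccc12` differs from compound 3 by acetyl in place of hydrogen on an amine nitrogen. Since the two measured steps show that adding a group on that nitrogen in place of hydrogen removes most of the inhibition, a large drop is expected, a number 46 percentage points lower from compound 3 to compound 4 (beyond the scatter). For compound 4 the estimate in this assay is therefore 0%, within -20% to 25%.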

Compound 4, a percentage reported as inhibition, at one concentration (the size of the read-out at that concentration, not a potency): 57.5%
Compound 4: the middle estimate sits 57.5 percentage points below what was measured, and the stated range ends below it.
By their numbers in this assay, from the lowest: compounds 1 and 2 (each within the scatter of the next); then compound 3; then compound 4.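

In this assay, a substituent on the amine nitrogen does not by itself remove inhibition: with acetyl in place of hydrogen the number is not lost but stands a number 11.5 percentage points higher from compound 3 to compound 4 (beyond the scatter). The outcome depends on which group sits there, with acetyl standing apart from benzyl, a number 70.6 percentage points higher from compound 2 to compound 4 (beyond the scatter), and from (4-methylphenyl)sulfonyl, a number 71.4 percentage points higher from compound 1 to compound 4 (beyond the scatter). Nothing available here accounts for this difference. The compounds shown leave open whether a longer acyl chain such as propanoyl would match acetyl. They also leave open how a methyl or a methanesulfonyl group on that nitrogen would read.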